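Swapping the ester group on a dihydropyridine calcium-channel blocker

This account rests on a few compounds, and the source may have more. Where it says the series, first, only, none or still open, it means among the compounds named here.

Measured so far in a functional assay on HEK293 cells for antagonist activity at Voltage-dependent L-type calcium channel subunit alpha-1C (Oryctolagus cuniculus), read by FLIPR; a higher number here means a weaker inhibitor, a lower number a stronger inhibitor:
- compound 1, `C=C(C)CCOC(=O)C1=C(C)NC(C)=C(C(=O)OC)C1c1cccc([N+](=O)[O-])c1`, gives 23 nM
- compound 2, `COC(=O)C1=C(C)NC(C)=C(C(=O)OCC(C)[N+](=O)[O-])C1c1cccc([N+](=O)[O-])c1`, gives 108 nM
- compound 3, `COC(=O)C1=C(C)NC(C)=C(C(=O)OCc2ccc(F)c(F)c2)C1c1cccc([N+](=O)[O-])c1`, gives 7 nM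

Compound 3 stands lowest of the three, and both gaps to it lie beyond the scatter: a 3.3-fold lower number from compound 1 to compound 3 (0.52 log units; beyond the scatter) and a 15-fold lower number from compound 2 to compound 3 (1.19 log units; beyond the scatter). The step of a 4.7-fold higher number from compound 1 to compound 2 (0.67 log units; beyond the scatter) shows that the group on this ester carbon moves the number modestly in either direction.

Compound 4, `COC(=O)C1=C(C)NC(C)=C(C(=O)OCCOc2ccccc2Cl)C1c1cccc([N+](=O)[O-])c1`, differs from compound 3 only there: (2-chlorophenoxy)methyl in place of 3,4-difluorophenyl on a saturated chain carbon bound to an oxygen next to a carbonyl group. Within the data shown here, no measured step exchanges one aromatic group for another, so the three steps bear on it only by showing that the ester group matters, and that an aromatic ring here gave the lowest number. Because compound 3 gives 7 nM and compound 4 keeps an aromatic ring, a small step is expected, a 1.7-fold higher number from compound 3 to compound 4 (0.23 log units; within the scatter), with direction uncertain. Compound 4 is estimated at 12 nM, in the range 4 nM to 40 nM.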

Compound 4, half-maximal inhibitory concentration: 19 nM
Beside the measured number, compound 4's estimate is 1.6-fold (0.20 log units) below it; measured number inside the range.
By their numbers in this assay, from the lowest: compound 3; then compounds 4 and 1 (each within the scatter of the next); then compound 2.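

In this assay, exchanging one aromatic group for another at this ester position still moves the number, so the ring alone does not set it: 3,4-difluorobenzyl giving way to 2-(2-chlorophenoxy)ethyl produces a 2.7-fold higher number from compound 3 to compound 4 (0.43 log units; beyond the scatter). Compound 4 keeps a clear lead over the 1-nitroethyl-bearing ester, with a 5.7-fold lower number from compound 2 to compound 4 (0.75 log units; beyond the scatter), yet it cannot be told apart from the non-aromatic ester, with a 1.2-fold lower number from compound 1 to compound 4 (0.08 log units; within the scatter), so an aromatic ring here does not by itself give a lower number than compound 1 does. No measurement is available that would explain any of these steps.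

Going by these compounds, this single change replaces the fluorines with a chlorine and also adds an oxygen to the chain, so the contribution of each stays open. On these data alone, how an amine or a carboxylic acid on this ester chain would compare also remains unknown.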